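A few compounds are considered here, and "the series" means these few. Any claim that something is new, unique, unknown or untested is made for them only; others in the source may bear on it.

Values in a functional assay on CNE-2 cells (Homo sapiens) for antiproliferative activity, read by sulforhodamine B assay, with a stated time of 48 h; a higher number here means a weaker inhibitor, a lower number a stronger inhibitor:

- compound 1 `COc1cc(C=C(C(=O)/C=C/c2cccc(OC)c2OC)C(=O)/C=C/c2cccc(OC)c2OC)cc(Br)c1O`: 220 nM
- compound 2 `COc1ccc(/C=C/C(=O)C(=Cc2ccc(O)c(OC)c2)C(=O)/C=C/c2ccc(OC)cc2OC)c(OC)c1`: 970 nM

Compound 2, at 970 nM, holds the higher of the two numbers, and the gap to compound 1, at 220 nM, lies beyond the scatter.

Next is compound 3 `COc1ccc(/C=C/C(=O)C(=Cc2cc(Br)c(O)c(OC)c2)C(=O)/C=C/c2ccc(OC)cc2OC)c(OC)c1`, which turns the 4-hydroxy-3-methoxyphenyl of compound 2 into 3-bromo-4-hydroxy-5-methoxyphenyl: bromo in place of hydrogen on an aromatic carbon. The bromo sits ortho to a hydroxy group and meta to a methoxy group.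

Going by the values given here, no measured pair isolates this change, so the evidence is thin. Compound 1 carries the same 3-bromo-4-hydroxy-5-methoxyphenyl group and gives 220 nM, which points to a lower number in this assay, of modest size and perhaps only just beyond the scatter. The expected step is a 2.3-fold lower number from compound 2 to compound 3 (0.36 log units; beyond the scatter). Compound 3 is estimated at 420 nM, with an expected range of 170 nM to 1000 nM.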

Compound 3, half-maximal inhibitory concentration: 1780 nM
Estimate against measurement, compound 3: 4.2-fold (0.63 log units) below; the whole stated range lies below it.
By their numbers in this assay, from the lowest: compound 1; then compounds 2 and 3 (each within the scatter of the next).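

In this assay, going by these compounds alone, the first pair to isolate bromo in place of hydrogen on an aromatic carbon shows a 1.8-fold higher number from compound 2 to compound 3 (0.26 log units; within the scatter) with the bromo ortho to a hydroxy group and meta to a methoxy group. On the core of compound 2 this position therefore does not separate bromo from hydrogen, and carrying the 3-bromo-4-hydroxy-5-methoxyphenyl group does not by itself bring a lower number on that core. Nothing at hand bears on why this change leaves the number within the scatter.

Still open, from the compounds shown here alone, is whether a different group at this position, such as chloro, an amine or a carboxylic acid, would give a step beyond the scatter. Also open, going by these compounds, is whether bromo in place of hydrogen gives a step of similar size on the core of compound 1.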